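The compounds below may be only part of what the source reports. "The series", "measured", "known", "first", "only" and "open" are said of these compounds alone.

Compound 1 `COc1cc(-c2nn(-c3cccc(NC(=O)Nc4ccc(Cl)c(Cl)c4)c3)cc2-c2ccncc2)ccc1Cl` gives 1430 nM in a functional assay on TK-10 cells (Homo sapiens) for inhibition, read by sulforhodamine B assay, with a stated time of 48 h; a higher number here means a weaker inhibitor of growth, a lower number a stronger inhibitor of growth.
Compound 2 `COc1cc(-c2nn(-c3cccc(NC(=O)c4ccc(Cl)c(C(F)(F)F)c4)c3)cc2-c2ccncc2)ccc1Cl` gives 20400 nM in this assay.

Compound 2 stands at the highest of the two numbers in this assay: its nearest neighbour is compound 1, and the step of a 14-fold higher number from compound 1 to compound 2 (1.15 log units; beyond the scatter) is large and beyond the scatter. That step, however, alters two things at once: the carbonyl carbon loses its attached nitrogen and the aromatic ring changes its substituents, so it only partly bears on what follows.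

Compound 3 `COc1cc(-c2nn(-c3cccc(NC(=O)Nc4ccc(Cl)c(C(F)(F)F)c4)c3)cc2-c2ccncc2)ccc1Cl` differs from compound 2 in one place: (4-chloro-3-(trifluoromethyl)phenyl)amino in place of 4-chloro-3-(trifluoromethyl)phenyl on a carbonyl carbon. This returns the carbonyl carbon to the arrangement of compound 1 while keeping the ring of compound 2. Going by the values given here, no measured pair isolates this change alone, but compound 1, the only compound carrying an amino group on the carbonyl carbon, sits far below compound 2 in this assay, so a step downward, beyond the scatter, is expected for compound 3, of the order of a 10-fold lower number from compound 2 to compound 3 (1.01 log units; beyond the scatter). Compound 3 is therefore estimated at 2000 nM in this assay, within a range of 600 nM to 7000 nM.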

Compound 3, concentration for 50% growth inhibition: 1520 nM
Compound 3: middle estimate off by 1.3-fold (0.12 log units), on the high side; the range from low to high includes it.
By their numbers in this assay, from the lowest: compounds 1 and 3 (each within the scatter of the next); then compound 2.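

In this assay, with the 4-chloro-3-(trifluoromethyl)phenyl group held constant, (4-chloro-3-(trifluoromethyl)phenyl)amino in place of 4-chloro-3-(trifluoromethyl)phenyl on the carbonyl carbon gives a 13-fold lower number from compound 2 to compound 3 (1.13 log units; beyond the scatter) and so isolates a large step, beyond the scatter, toward stronger inhibition of growth. The exchange of trifluoromethyl in place of chloro on an aromatic carbon gives a 1.1-fold higher number from compound 1 to compound 3 (0.03 log units; within the scatter) and stays within the scatter, so among the single-place comparisons, only the change on the carbonyl carbon moves the number. Nothing available here explains why the amino link makes this difference.

The compounds shown leave open whether a methylamino link, an oxygen link or a methylene link on the carbonyl carbon would keep the number near those of compound 1 and compound 3, since only the amino link and the direct attachment of the ring can be compared. They also leave open whether a fluoro, methoxy or nitrile group on the aromatic ring would behave like chloro and trifluoromethyl, which cannot be told apart in this pair.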